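Trifluoromethyl for Methyl on Two Related Cores

The source may hold more compounds than are shown below. What is called first, only, known or untested is meant among the compounds shown, and "the series" means these compounds.

Compound 2 `Cc1cc(OCc2nc(N)nc(Nc3ccc(C)c(Cl)c3)n2)cc(N2CCCC2=O)c1`: 20 nM
Compound 1 `Cc1ccc(Nc2nc(N)nc(COc3cc(N4CCCC4=O)cc(C(F)(F)F)c3)n2)cc1Cl`: 3190 nM
Compound 3 `Cc1ccc(Nc2nc(N)nc(COc3cc(N4CCCC4=O)ccc3C)n2)cc1Cl`: 7450 nM

All three were tested in an assay on COS-7 cells for agonist activity at Free fatty acid receptor 1 (Homo sapiens), read by scintillation counting and inositol phosphate accumulation, with a stated time of 90 min; a higher number here means that more compound is needed for the effect, a lower number that less compound is needed. Compound 2 and compound 1 share a core and differ in one place: trifluoromethyl in place of methyl on an aromatic carbon. This change made a 160-fold higher number from compound 2 to compound 1 (2.20 log units; beyond the scatter), so compound 1 needs far more compound than compound 2 for the same effect. Compound 3 has the same atoms as compound 2 joined differently; the difference between the two cores is not broken down here. In this assay compound 3 gives 7450 nM, the highest number of the three.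

Compound 4 `Cc1ccc(Nc2nc(N)nc(COc3cc(N4CCCC4=O)ccc3C(F)(F)F)n2)cc1Cl` is not yet measured. It is made from compound 3 by trifluoromethyl in place of methyl on an aromatic carbon. This is the same kind of change as from compound 2 to compound 1, not the same one: in the earlier pair the new group sits meta to the 2-oxopyrrolidin-1-yl group and meta to a large group, while in compound 4 it sits ortho to a large group and para to the 2-oxopyrrolidin-1-yl group. Because the earlier step was a 160-fold higher number from compound 2 to compound 1 (2.20 log units; beyond the scatter), a rise in the number for compound 4 is expected, but the different surroundings and the already high number of compound 3 make a smaller step the likelier estimate: a 4.0-fold higher number from compound 3 to compound 4 (0.60 log units; beyond the scatter). Compound 4 is thus expected to give about 30000 nM, estimated between 7000 nM and 150000 nM, with a real chance that only a limit is reported.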

Compound 4, half-maximal effective concentration: 20100 nM
The estimate for compound 4 lay 1.5-fold (0.17 log units) above the measured number; the range from low to high includes it.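

In this assay, putting trifluoromethyl in place of methyl on an aromatic carbon raised the number again, a 2.7-fold higher number from compound 3 to compound 4 (0.43 log units; beyond the scatter), so in both pairs shown the change goes the same way, towards more compound being needed. The size of the step did not carry over from one core to the other: the same change on two cores in this assay, a 160-fold higher number (2.20 log units; beyond the scatter) from compound 2 to compound 1 and a 2.7-fold higher number (0.43 log units; beyond the scatter) from compound 3 to compound 4, 59-fold (1.77 log units) apart, beyond the scatter of two such steps

What this does not show is why the two steps differ, since the pairs differ both in their core and in where the new group sits, and compound 2 starts at 20 nM while compound 3 starts at 7450 nM; two pairs cannot separate these factors, nor do they give a rule for a further core.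

The compounds shown leave open how other groups on the same aromatic carbon would behave, such as a chlorine, a methoxy group or a nitrile, and whether any of them would fall nearer to methyl or to trifluoromethyl. They also leave open whether moving trifluoromethyl to another carbon of the ring within a single core would alter the number, a comparison that would separate the effect of place from the effect of core.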